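Carbamate and carbonate tails on a shared core: cell tolerability

A few compounds are considered here, and "the series" means these few. Any claim that something is new, unique, unknown or untested is made for them only; others in the source may bear on it.

Measured in a functional assay on MT4 cells (Homo sapiens) for cytotoxicity; a higher number here means that more compound is tolerated, a lower number that less compound is tolerated:
compound 1 `Cc1cn(C2CC(N=[N+]=[N-])C(COC(=O)NCCCO)O2)c(=O)[nH]c1=O`: > 50000 nM
compound 2 `Cc1cn(C2CC(N=[N+]=[N-])C(COC(=O)OCCCCCCO)O2)c(=O)[nH]c1=O`: > 50000 nM
compound 3 `Cc1cn(C2CC(N=[N+]=[N-])C(COC(=O)NCCCN)O2)c(=O)[nH]c1=O`: > 50000 nM

Each of these values is a limit, not a number. For compound 2 the limit is all that is known. The steps a step that the two limits leave unreadable from compound 1 to compound 2, a step that the two limits leave unreadable from compound 2 to compound 3 and a step that the two limits leave unreadable from compound 1 to compound 3 are all unreadable, since every value shown sits at the limit of > 50000 nM in this assay, at which 3 of the 3 values shown sit. Compound 4 `Cc1cn(C2CC(N=[N+]=[N-])C(COC(=O)OCCCO)O2)c(=O)[nH]c1=O` differs from compound 2 by hydroxy in place of 3-hydroxypropyl on a saturated chain carbon, three bonds along the chain from an oxygen next to a carbonyl group. Within the data shown here, no measured step bears on this change, so nothing points either way. With its neighbours all at the limit, compound 4 is expected to remain there, meaning an estimated step that the limit leaves unreadable from compound 2 to compound 4 in this assay. The estimate for compound 4 is 60000 nM, with a range from 30000 nM to 200000 nM.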

Compound 4, half-maximal cytotoxic concentration: > 50000 nM
Compound 4 gave a limit, no number; the forecaster's own chance of this, stated with the estimate: 85%; the middle value does not contradict the limit.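

Compound 4 adds no readable step against compound 1, compound 2 or compound 3, since all four sit at a single limit: the limit of > 50000 nM in this assay, at which 4 of the 4 values shown sit. The compounds shown leave open whether any of these tails changes cell tolerability.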